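A few compounds are considered here, and "the series" means these few. Any claim that something is new, unique, unknown or untested is made for them only; others in the source may bear on it.

Compound 3 `CN(C)CCn1cnnc1-c1cc(Oc2ccc(NC(=O)N/N=C/c3ccc(Cl)cc3)cc2F)ccn1` stands lowest among the two numbers recorded in a functional assay on U-87MG ATCC cells (Homo sapiens) for cytotoxicity, read by MTT assay, with a stated time of 72 h (on this read-out higher numbers stand for weaker inhibition and lower numbers for stronger inhibition), where compound 3 gives 1370 nM. Compound 1 `COc1ccc(/C=N/NC(=O)Nc2ccc(Oc3ccnc(-c4nncn4CCN(C)C)c3)c(F)c2)c(OC)c1OC` gives 7650 nM in this assay, and there is a 5.6-fold lower number from compound 1 to compound 3 (0.75 log units; beyond the scatter). Compound 2 `CN(C)CCn1cnnc1-c1cc(Oc2ccc(NC(=O)N/N=C/c3cc(Br)c(O)c(Br)c3)cc2F)ccn1` reaches only a limit of this assay, > 100000 nM, which is the limit of > 100000 nM in this assay, at which 1 of the 3 values shown sits. Compound 4 `CN(C)CCn1cnnc1-c1cc(Oc2ccc(NC(=O)N/N=C/c3ccc(O)cc3O)cc2F)ccn1` differs from compound 3 in one place: 2,4-dihydroxyphenyl in place of 4-chlorophenyl on a carbon with a double bond to nitrogen. Within the data shown here, two measured steps bear on the change of this aryl group, a 5.6-fold lower number from compound 1 to compound 3 (0.75 log units; beyond the scatter) and an at least 72-fold lower number from compound 2 to compound 3 (1.86 log units; beyond the scatter), both showing that the 4-chlorophenyl ring gives the lowest number and that a hydroxyl-bearing ring gave the highest. Compound 4 is therefore expected to give a higher number, estimated at 12000 nM, with a range from 2500 nM to 60000 nM. The expected step is an 8.8-fold higher number from compound 3 to compound 4 (0.94 log units; beyond the scatter).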

Compound 4, half-maximal inhibitory concentration: 15400 nM
The estimate for compound 4 lay 1.3-fold (0.11 log units) below the measured number; the range from low to high includes it.
By their numbers in this assay, from the lowest: compound 3; then compounds 1 and 4 (each within the scatter of the next). At a limit, above all of these: compound 2.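

Replacing 4-chlorophenyl with 2,4-dihydroxyphenyl on this carbon gives a second hydroxyl-bearing ring that raises the number, with an 11-fold higher number from compound 3 to compound 4 (1.05 log units; beyond the scatter). Hydroxyl-bearing rings still differ from one another, with an at least 6.4-fold lower number from compound 2 to compound 4 (0.81 log units; beyond the scatter), a step read against a value that is only a limit: the limit of > 100000 nM in this assay, at which 1 of the 4 values shown sits. The 2,4-dihydroxyphenyl and 2,3,4-trimethoxyphenyl rings cannot be separated, with a 2.0-fold higher number from compound 1 to compound 4 (0.30 log units; within the scatter).

From the compounds shown here alone, what a plain phenyl, 4-fluorophenyl or 4-hydroxyphenyl ring would give on this carbon stays open. So does whether the chlorine itself or the lack of hydroxyl sets compound 3 apart.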